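The compounds below may be only part of what the source reports. "The series", "measured", "known", "first", "only" and "open" are said of these compounds alone.

Measured compounds in an ADME assay (liver) for metabolic stability, with Liver microsome (Homo sapiens) as the target, using microsomes, with a stated time of 10 min; on this read-out higher numbers stand for a more stable compound and lower numbers for a less stable compound:
Compound 1, `CCCc1cnc(N2CCC(C3Cc4c(F)c(C5=CCN(S(=O)(=O)CCC)CC5)cc(F)c4O3)CC2)nc1`, gives 78%.
Compound 2, `CCCc1cnc(N2CCC(C3(C)Cc4cc(C5=CCN(S(=O)(=O)CCC)CC5)ccc4O3)CC2)nc1`, gives 68%.
Compound 3, `CCCc1cnc(N2CCC(C3Cc4c(F)c(C5=CCN(S(=O)(=O)CCCO)CC5)cc(F)c4O3)CC2)nc1`, gives 89%.

Compound 3 differs from compound 1 by hydroxy in place of hydrogen on a saturated chain carbon, three bonds along the chain from a sulfonyl sulfur, and this step reads a number 11 percentage points higher from compound 1 to compound 3 (beyond the scatter). Compound 2 stands on a different core from compound 1; the difference between the two cores is not broken down here. Compound 4, `CCCc1cnc(N2CCC(C3(C)Cc4cc(C5=CCN(S(=O)(=O)CCCO)CC5)ccc4O3)CC2)nc1`, has not yet been measured; it differs from compound 2 by hydroxy in place of hydrogen on a saturated chain carbon, three bonds along the chain from a sulfonyl sulfur, the same change as that from compound 1 to compound 3. Since the step of a number 11 percentage points higher from compound 1 to compound 3 (beyond the scatter) was modest but beyond the scatter, a step of similar size is expected here, a number 11 percentage points higher from compound 2 to compound 4 (beyond the scatter). Compound 4 is therefore estimated to give 79%, most likely between 68% and 90%.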

Compound 4, percent of the compound remaining: 72%
Beside the measured number, compound 4's estimate is 7 percentage points above it; the measured number falls inside the stated range.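

In this assay, the change from propyl to 3-hydroxypropyl reads a number 4 percentage points higher from compound 2 to compound 4 (within the scatter). Set beside the earlier step, this one does not differ from it: the same change on two cores in this assay, a number 11 percentage points higher (beyond the scatter) from compound 1 to compound 3 and a number 4 percentage points higher (within the scatter) from compound 2 to compound 4, 7 percentage points apart, within the scatter of two such steps. For the compounds shown here, the two cores are therefore compatible with a shared effect of this change, but this does not show that the effect carries over, as only one of the two steps stands clear of the scatter and each core offers a single pair.

Going by these compounds, it remains open whether an amine, a carboxylic acid or a longer chain in place of the 3-hydroxypropyl group would behave alike on both cores. On these data alone, whether the change would read the same on any further core also remains open.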